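This account rests on a few compounds, and the source may have more. Where it says the series, first, only, none or still open, it means among the compounds named here.

Measured in a functional assay on PC-3 cells (Homo sapiens) for cytotoxicity, read by colorimetric assay and MTT assay; on this read-out lower numbers stand for stronger inhibition and higher numbers for weaker inhibition:
compound 1 `COc1ccc(-c2cc3c(OC)cc(OC)cc3n(CCCC#N)c2=O)cc1` gives 10000 nM
compound 2 `COc1ccc(-c2cc3c(OC)cc(OC)cc3n(CC(=O)OCc3ccccc3)c2=O)cc1` gives 10000 nM
compound 3 `COC(=O)CCn1c(=O)c(-c2ccc(OC)cc2)cc2c(OC)cc(OC)cc21` gives 10000 nM

Going by the values given here, compound 3 stands level with compound 1 and compound 2 at the digits reported, so the series so far shows no spread. Compound 4 `COc1ccc(-c2cc3c(OC)cc(OC)cc3n(CCC(=O)OCc3ccccc3)c2=O)cc1` is compound 3 with one change: phenyl in place of hydrogen on a saturated chain carbon bound to an oxygen next to a carbonyl group. This is phenyl in place of hydrogen on a saturated chain carbon bound to an oxygen next to a carbonyl group, which reads as methoxycarbonyl to benzyloxycarbonyl.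

The closest evidence is no change at the digits printed from compound 2 to compound 3 (within the scatter), which exchanges the same two ester groups together with a change in the chain. The other two measured steps are no change at the digits printed from compound 1 to compound 2 (within the scatter) and no change at the digits printed from compound 1 to compound 3 (within the scatter). None of the three leaves the scatter, and compound 2 already carries benzyloxycarbonyl at 10000 nM. No step beyond the scatter is therefore expected in this assay, and no direction can be assigned. The expected outcome is no change at the digits printed from compound 3 to compound 4 (within the scatter). Compound 4 is estimated at 10000 nM, with an expected range from 5000 nM to 20000 nM.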

Compound 4, half-maximal inhibitory concentration: 10000 nM
Compound 4: the middle estimate sits on the measured number at the digits printed; measured number inside the range.
By their numbers in this assay, from the lowest: compounds 1, 2, 3 and 4 (each within the scatter of the next).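

In this assay, the methoxycarbonyl to benzyloxycarbonyl exchange can now be read alone on the same chain, with no chain difference mixed in (no change at the digits printed from compound 3 to compound 4 (within the scatter)). The added phenyl therefore leaves this ester position level with the methyl ester at the digits printed. The two other new comparisons read the same way (no change at the digits printed from compound 2 to compound 4 (within the scatter); no change at the digits printed from compound 1 to compound 4 (within the scatter)), so neither benzyloxycarbonyl on this chain nor the further substituent differences separate these compounds. Nothing at hand offers an explanation for this flat reading.

Open, going by these compounds, is whether a carboxylic acid or an amine at the chain end, or a longer chain, would separate from compound 4 at 10000 nM in this assay. Also open, on these data alone, is whether any substituent on the shared core would give a lower number.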